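The source may hold more compounds than are shown below. What is called first, only, known or untested is meant among the compounds shown, and "the series" means these compounds.

Of the compounds shown here, three built on one shared core have so far been tested in an assay on cells for inhibition of Voltage-dependent T-type calcium channel subunit alpha-1H (Homo sapiens), read by patch clamp; on this read-out lower numbers stand for stronger inhibition and higher numbers for weaker inhibition. Compound 1 `CN(C)CCCCCSC1=Nc2ccccc2C(CC(=O)NCc2ccc(F)cc2)N1c1ccc(-c2ccccc2)cc1` gives 3140 nM in this assay. Compound 2 `O=C(CC1c2ccccc2N=C(SCCCCCN2CCCC2)N1c1ccc(-c2ccccc2)cc1)NCc1ccc(F)cc1` gives 276000 nM in this assay, the highest of the three numbers. Compound 3 `CN(C)CCCCCSC1=Nc2ccccc2C(CC(=O)NCc2ccccc2)N1c1ccc(-c2ccc(F)cc2)cc1` gives 4180 nM in this assay; it differs from compound 1 in two places, so its number simply stands beside that of compound 1. Among the compounds with values here, the only single-point step among the measured compounds is an 88-fold higher number from compound 1 to compound 2 (1.94 log units; beyond the scatter), a change at the end of the saturated chain, far from the ring that carries the large group.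

Compound 4 `O=C(CC1c2ccccc2N=C(SCCCCCN2CCCC2)N1c1ccccc1)NCc1ccc(F)cc1` has not yet been measured. Set against compound 2 it shows (hydrogen in place of phenyl on an aromatic carbon), the place being para to a large group. Within the data shown here, no measured step touches that ring, so the size and direction of the step are open. With nothing to anchor it, compound 4 is expected to stay near compound 2, giving an estimated step of a 1.4-fold lower number from compound 2 to compound 4 (0.14 log units; within the scatter) in this assay, with a wide range. Compound 4 is therefore estimated at 200000 nM in this assay, expected to fall between 40000 nM and 1000000 nM.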

Compound 4, half-maximal inhibitory concentration: 57400 nM
Compound 4: the middle estimate sits 3.5-fold (0.54 log units) above what was measured, within the range that was stated.
By their numbers in this assay, from the lowest: compounds 1 and 3 (each within the scatter of the next); then compound 4; then compound 2.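

Within the data shown here, replacing the outer phenyl with hydrogen, so that 4-phenylphenyl becomes phenyl, is the first measured change on this ring. In this assay it gives a 4.8-fold lower number from compound 2 to compound 4 (0.68 log units; beyond the scatter), so on the pyrrolidin-1-yl chain, removing this ring of six carbon atoms strengthens inhibition modestly rather than weakening it. This change at the ring is much smaller than the one at the chain end, an 88-fold higher number from compound 1 to compound 2 (1.94 log units; beyond the scatter), and nothing provided explains the direction or size of either step.

On these data alone, it remains open whether removing the phenyl would have a similar effect on a chain ending in dimethylamino, as in compound 1, since this step has been read only with pyrrolidin-1-yl at the chain end. The compounds also leave open how inhibition would respond to other groups at this ring position, such as a methyl group, a chlorine atom or a cyclohexyl ring, which would show whether the trend follows the size of the group or something specific to the phenyl ring.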